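The source may report more compounds than this note shows. Statements on the series, on what has been measured and on what is new or still open speak of the compounds shown alone.

Of the compounds shown here, two have been measured in a functional assay on DU-145 cells (Homo sapiens) for cytotoxicity, read by trypan blue exclusion, with a stated time of 96 h; a lower number here means a stronger inhibitor, a higher number a weaker inhibitor. Compound 1, `COc1ccc(/C=C/S(=O)(=O)Cc2ccc(OC)c(N)c2)cc1`, carries a single methoxy group and a bare amino group on the benzyl ring; in this assay compound 1 gives 2500 nM. Compound 2, `COC(=O)[C@H](C)Nc1cc(CS(=O)(=O)/C=C/c2c(OC)cc(OC)cc2OC)ccc1OC`, has three methoxy groups on the styryl ring and an amino nitrogen substituted with a 1-(methoxycarbonyl)ethyl group; in this assay compound 2 gives 750 nM, the lower of the two numbers, and the gap between compound 2 and compound 1 lies beyond the usual scatter.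

Compound 3, `COc1cc(OC)c(/C=C/S(=O)(=O)Cc2ccc(OC)c(NC(C)(C)C(=O)O)c2)c(OC)c1`, keeps the whole of compound 2 apart from one change: 1-carboxy-1-methylethyl in place of 1-(methoxycarbonyl)ethyl on a nitrogen on an aromatic ring. The atoms are the same and only their arrangement differs, so the two compounds are close in size and composition.

Within the data shown here, no measured pair shows this kind of change, so the expectation rests on the closeness of the two structures alone. The step from compound 2 to compound 3 is expected to be small, a 1.3-fold higher number from compound 2 to compound 3 (0.12 log units; within the scatter), leaning toward a slightly higher number but not clearly beyond the scatter. Compound 3 is therefore estimated at 1000 nM, with a range from 400 nM to 2500 nM.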

Compound 3, half-maximal inhibitory concentration: 150 nM
Estimate against measurement, compound 3: 6.7-fold (0.82 log units) above, outside the stated range (below it).
By their numbers in this assay, from the lowest: compound 3; then compound 2; then compound 1.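

In this assay, the substituent on a nitrogen on an aromatic ring proves able to shift the number with the rest of the molecule held constant: 1-carboxy-1-methylethyl in place of 1-(methoxycarbonyl)ethyl gives a 5.0-fold lower number from compound 2 to compound 3 (0.70 log units; beyond the scatter). The earlier compounds shown here differed in more than one place and could not isolate this nitrogen substituent, whereas here the atoms are the same and the two groups have the same heavy-atom count, so the step belongs to their arrangement, which brings one hydrogen-bond donor, one hydrogen-bond acceptor rather than two, and no defined stereocentre. Nothing available explains why this rearrangement goes with the lower number.

The single step bundles the free carboxylic acid with the second methyl group on the carbon attached to the nitrogen, so the compounds shown do not tell which of these features goes with the change. A 1-carboxyethyl group, with the acid and only one methyl, or a 1-(methoxycarbonyl)-1-methylethyl group, with the ester and both methyls, would separate the two, and the compounds shown also leave open how a longer chain between the nitrogen and the carboxylic acid would read.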